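Thiazole for thiophene on a shared anilide core

The source may hold more compounds than are shown below. What is called first, only, known or untested is meant among the compounds shown, and "the series" means these compounds.

Compound 1 `O=C(Nc1ccc(Cl)cc1)C1CCCN(C(=O)c2cccc(-c3cccs3)c2)C1` and compound 2 `O=C(Nc1ccc(Cl)cc1)C1CCCN(C(=O)c2cc(C(F)(F)F)cc(C(F)(F)F)c2)C1` share a core and were both run in an ADME assay on PC-3 cells (Homo sapiens) for cytotoxicity, read by WST assay, tested at 100 uM; a lower number here means less inhibition, a higher number more inhibition at the concentration tested (going by the name of the read-out). In this assay compound 1 gives 4%; compound 2 gives 14%, which lies within the usual scatter of compound 1, so the two numbers cannot be ordered. Compound 3 `Cc1nc(-c2cccc(C(=O)N3CCCC(C(=O)Nc4ccc(Cl)cc4)C3)c2)cs1` awaits measurement. Against compound 1 the change is 2-methyl-1,3-thiazol-4-yl in place of thiophen-2-yl on an aromatic carbon, on an aromatic carbon of a six-membered aromatic ring of carbon only. Among the measured compounds shown here, no measured pair shows this change, so no step beyond the scatter is expected; the expected step is a number 3 percentage points higher from compound 1 to compound 3 (within the scatter). Compound 3 is estimated at 7%, between -5% and 22%.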

Compound 3, a percentage reported as inhibition, at one concentration (the size of the read-out at that concentration, not a potency): 1%
Compound 3: the middle estimate sits 6 percentage points above what was measured; the range from low to high includes it.
By their numbers in this assay, from the lowest: compounds 3, 1 and 2 (each within the scatter of the next, the first and the last beyond it).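

At this position, on an aromatic carbon of a six-membered aromatic ring of carbon only, 2-methyl-1,3-thiazol-4-yl in place of thiophen-2-yl gives a number 3 percentage points lower from compound 1 to compound 3 (within the scatter) in this assay. Among the compounds shown here, this exchange of one five-membered aromatic ring for another therefore gives no step that can be read in this read-out. Nothing available bears on why the two compounds read alike.

Still open, as far as these compounds go, is whether a carboxylic acid or an amine at the same place would give a number beyond the scatter of compound 1.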